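A few compounds are considered here, and "the series" means these few. Any claim that something is new, unique, unknown or untested is made for them only; others in the source may bear on it.

Measured compounds in a functional assay on MCF7 cells (Homo sapiens) for cytotoxicity, read by MTT assay; a higher number here means a weaker inhibitor, a lower number a stronger inhibitor:
compound 1 `CC(C)[C@H](NC(=S)NCc1ccccc1)c1nc2ccccc2[nH]1` gives 57800 nM
compound 2 `CC(C)[C@@H](NC(=S)NCc1ccccc1)c1nc2ccccc2[nH]1` gives 11100 nM
compound 3 `C[C@@H](NC(=S)NCc1ccccc1)c1nc2ccccc2[nH]1` gives 14300 nM

Compound 3 stands second highest of the three numbers in this assay. Its nearest neighbour is compound 2: the step of a 1.3-fold higher number from compound 2 to compound 3 (0.11 log units; within the scatter) stays within the scatter, so the two cannot be ordered. Compound 1 stands further off, beyond the scatter.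

Compound 4 `C[C@H](NC(=S)NCc1ccccc1)c1nc2ccccc2[nH]1` is the next case. The change from compound 3 is the two compounds have the same atoms and bonds and differ only in configuration as drawn: 1 of 1 stereo elements differ; a stereocentre at a saturated chain carbon is drawn R in compound 3 and S in compound 4.

Within the data shown here, one measured step bears on this: compound 1 and compound 2 form the same kind of pair, and the fact that compounds 1 and 2 differ only in the configuration as drawn is the only thing that separates them. There the step of a 5.2-fold lower number from compound 1 to compound 2 (0.72 log units; beyond the scatter) ran from the S-drawn to the R-drawn centre. The step from compound 3 to compound 4 runs the opposite way, from R to S, so a step of similar size in the other direction is expected in this assay, that is a higher number for compound 4, beyond the scatter. Among the measured compounds shown here, the isopropyl-to-methyl change has not been seen on the S-drawn side, so the size is taken from the single pair available.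

For compound 4 the expected step is a 3.8-fold higher number from compound 3 to compound 4 (0.59 log units; beyond the scatter). The estimate for compound 4 in this assay is 55000 nM, with a range from 20000 nM to 150000 nM.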

Compound 4, half-maximal inhibitory concentration: 217000 nM
Estimate against measurement, compound 4: 3.9-fold (0.60 log units) below; the measured number lies above the stated range.
By their numbers in this assay, from the lowest: compounds 2 and 3 (each within the scatter of the next); then compound 1; then compound 4.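

In this assay the S-drawn centre again carries the higher number, now with a 15-fold higher number from compound 3 to compound 4 (1.18 log units; beyond the scatter), so the direction seen in the isopropyl pair also holds in the methyl pair, and nothing but the configuration separates the two compounds: the fact that compounds 3 and 4 differ only in the configuration as drawn. Methyl in place of isopropyl can now be read on the S-drawn side as well, with a 3.8-fold higher number from compound 1 to compound 4 (0.57 log units; beyond the scatter), whereas on the R-drawn side the same change stayed within the scatter. The outcome of this change at the saturated chain carbon therefore depends on the configuration drawn there: the same change on two cores in this assay, a 1.3-fold higher number (0.11 log units; within the scatter) from compound 2 to compound 3 and a 3.8-fold higher number (0.57 log units; beyond the scatter) from compound 1 to compound 4, 2.9-fold (0.46 log units) apart, beyond the scatter of two such steps.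

Going by these compounds, whether the higher number on the S-drawn side and this dependence on configuration hold for other groups on that carbon, such as an ethyl, a cyclopropyl or a hydroxymethyl group, stays open. The four compounds also leave open why the S-drawn centre carries the higher number, and whether the same order would appear in cells other than MCF7.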